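This account rests on a few compounds, and the source may have more. Where it says the series, first, only, none or still open, it means among the compounds named here.

The measured compounds, all in a toxicity assay on HT-29 cells (Homo sapiens) for cytotoxicity; on this read-out lower numbers stand for higher toxicity in this test and higher numbers for lower toxicity in this test:

compound 1, `CC(C)n1nc(C(=O)N[C@H]2COc3ccccc3N(C)C2=S)nc1Cc1ccccc1`, gives > 100000 nM, which is a limit of the test and not a number.
compound 2, `CC(C)CCn1nc(C(=O)N[C@H]2COc3ccccc3N(C)C2=S)nc1Cc1ccccc1`, gives > 100000 nM, again a limit of the test.
compound 3, `CN1C(=S)[C@@H](NC(=O)c2nc(Cc3ccccc3)n(CCC(F)(F)F)n2)COc2ccccc21`, gives > 100000 nM, also a limit of the test.

Compound 1 thus stands at the limit of this assay, with no number of its own; the same holds for the two other measured compounds, as the limit of > 100000 nM in this assay, at which 3 of the 3 values shown sit, shows. The unmeasured compound 4, `CN1C(=S)[C@@H](NC(=O)c2nc(Cc3ccccc3)n(C3CCCCC3)n2)COc2ccccc21`, differs from compound 1 in one place: cyclohexyl in place of isopropyl on an aromatic nitrogen. The measured steps that bear on this change are a step that the two limits leave unreadable from compound 1 to compound 2 and a step that the two limits leave unreadable from compound 1 to compound 3, and among the other two compounds a step that the two limits leave unreadable from compound 2 to compound 3. None of them is readable in size, since both ends sit at the limit. The change to compound 4 is another exchange of the group on the same aromatic nitrogen, so it is expected to behave like those steps and to leave the compound at the limit, due to the limit of > 100000 nM in this assay, at which 3 of the 3 values shown sit. The step from compound 1 is therefore expected to be a number no higher from compound 1 to compound 4 (the limit leaves the size open). Compound 4 is estimated at 100000 nM in this assay, within a range of 50000 nM to 200000 nM, most likely again reported only as a limit.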

Compound 4, half-maximal cytotoxic concentration: > 100000 nM
Compound 4 ended at the assay's limit; the forecaster's own chance of this, stated with the estimate: 85%; the middle value sits exactly at the limit.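

Compound 4 sits at the limit of this assay, as do compound 1, compound 2 and compound 3, so no step among these compounds can be read in size: the limit of > 100000 nM in this assay, at which 4 of the 4 values shown sit.

The compounds shown leave open how far each lies beyond that limit, and whether any group on the aromatic nitrogen would give a measurable number.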